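Isopropyl for methyl on the aryl ring of compound 3

The source may hold more compounds than are shown below. What is called first, only, known or untested is meant among the compounds shown, and "the series" means these compounds.

The measured compounds and their values:
compound 1, `COc1cc(C(=O)Nc2nn[nH]n2)nc(-c2ccc(C(C)C)cc2)c1`, 54%
compound 2, `CCOc1cc(C(=O)Nc2nn[nH]n2)nc(-c2ccc(C)cc2)c1`, 65%
compound 3, `Cc1ccc(-c2cc(C)cc(C(=O)Nc3nn[nH]n3)n2)cc1`, 80%

In a functional assay on the whole organism with Rattus norvegicus as the target, at a dose of 1 mg/kg by the oral route (on this read-out higher numbers stand for a stronger effect at the one dose given and lower numbers for a weaker effect), compound 3 stands highest of the three numbers. Within the data shown here, its nearest neighbour is compound 2, and the one step that is measured as a single change, a number 15 percentage points higher from compound 2 to compound 3 (beyond the scatter), is of modest size. Compound 1 lies furthest below compound 3.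

Compound 4, `Cc1cc(C(=O)Nc2nn[nH]n2)nc(-c2ccc(C(C)C)cc2)c1`, differs from compound 3 in one place: isopropyl in place of methyl on an aromatic carbon. Among the measured compounds shown here, no measured pair changes only this group, so no step bears on it directly. For the measured compounds named here, compound 1 and compound 2 both carry the alkyl groups in question, but they differ in a second place as well, so their values show only that the compound with isopropyl gives the lower number of the two. On that thin basis compound 4 is expected to fall somewhat below compound 3, by a number 12 percentage points lower from compound 3 to compound 4 (beyond the scatter), a step that may not exceed the scatter. Compound 4 is therefore estimated at 68%, between 50% and 85%.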

Compound 4, a percentage reported as inhibition, in the whole organism at one dose (the size of the read-out at that dose, not a potency): 34%
Compound 4: the middle estimate sits 34 percentage points above what was measured; measured number below the stated range.
By their numbers in this assay, from the lowest: compound 4; then compound 1; then compound 2; then compound 3.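

In this assay, among these compounds, isopropyl in place of methyl on an aromatic carbon para to a large group gives a number 46 percentage points lower from compound 3 to compound 4 (beyond the scatter), so this position responds strongly to this single change, which no earlier pair had isolated. With isopropyl kept, methyl in place of methoxy gives a number 20 percentage points lower from compound 1 to compound 4 (beyond the scatter), whereas with methyl kept, methyl in place of ethoxy gave a number 15 percentage points higher from compound 2 to compound 3 (beyond the scatter), so the two replacements at that other aromatic carbon move the number in opposite directions on these two backgrounds. Nothing available explains either the large loss or this reversal.

The compounds shown leave open how the number would respond to an ethyl group or a chlorine atom at the position para to a large group. They also leave open whether ethoxy paired with isopropyl would follow the same reversal.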